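The compounds below may be only part of what the source reports. "The series", "measured", "known", "first", "only" and "open" are said of these compounds alone.

Compound 2 `O=C(NCc1ccc(CNS(=O)(=O)c2ccc(F)c(F)c2)cc1)c1ccc(F)cc1` gives 10 nM in an assay on MDA-MB-231 cells for binding affinity to C-X-C chemokine receptor type 4 (Homo sapiens), read by fluorescence and microscopy, with stated times of 10 min and 30 min (on this read-out higher numbers stand for an effect only at larger amounts of compound and lower numbers for an effect already at smaller amounts), and stands lowest of the two numbers measured; compound 1 `O=C(NCc1ccc(CNS(=O)(=O)c2ccc([N+](=O)[O-])cc2)cc1)c1ccc(F)cc1` gives 1000 nM in this assay, and the step of a 100-fold lower number from compound 1 to compound 2 (2.00 log units; beyond the scatter). Compound 3 `Cc1cccc(S(=O)(=O)NCc2ccc(CNC(=O)c3ccc(F)cc3)cc2)c1` carries 3-methylphenyl in place of 3,4-difluorophenyl on a sulfonyl sulfur. For the measured compounds named here, the only measured step concerns the same sulfonyl sulfur but exchanges a different group, so it shows only how strongly this position can move the number; no measured step involves a 3-methylphenyl. A modest rise is expected, a 3.0-fold higher number from compound 2 to compound 3 (0.48 log units; beyond the scatter). Compound 3 is estimated at 30 nM in this assay, with a range from 5 nM to 300 nM.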

Compound 3, effective concentration (reported as EC, without a stated level of effect): 1 nM
Compound 3: the middle estimate sits 30-fold (1.48 log units) above what was measured; measured number below the stated range.
By their numbers in this assay, from the lowest: compound 3; then compound 2; then compound 1.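

In this assay the 3-methylphenyl on a sulfonyl sulfur gives a 10-fold lower number from compound 2 to compound 3 (1.00 log units; beyond the scatter) and thus shows that this position tolerates a ring without fluorine and can still reach a lower number. Measured against the 4-nitrophenyl, it gives a 1000-fold lower number from compound 1 to compound 3 (3.00 log units; beyond the scatter) and so widens the span seen at this one position. Nothing at hand explains the gain from the 3-methylphenyl.

Still open, going by these compounds, is whether a methoxy group, an amine or a carboxylic acid on this ring would hold the low number. The compounds shown also leave open how changes elsewhere on the shared core would act.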